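A few compounds are considered here, and "the series" means these few. Any claim that something is new, unique, unknown or untested is made for them only; others in the source may bear on it.

Compound 2 `Cc1ccc(S(=O)(=O)N[C@@H](CC(=O)NC(C)(C)C)C(=O)NCCNC(=O)c2ccccc2)cc1` is the starting point of this comparison. In an ADME assay on HepG2 cells (Homo sapiens) for cytotoxicity (a lower number here means that less compound is needed, a higher number that more compound is needed for the effect), compound 2 gives only a limit of the assay, > 11000 nM, and not a number. The two related compounds that have been measured sit in the same place. Compound 1 `Cc1ccc(S(=O)(=O)N[C@@H](CC(=O)NC(C)(C)C)C(=O)NCCNC(=O)c2cc(C)ccc2F)cc1` gives in this assay a limit of the assay, > 11000 nM. Compound 3 `Cc1ccc(S(=O)(=O)N[C@@H](CC(=O)NC(C)(C)C)C(=O)NCCNC(=O)Nc2ccccc2)cc1` likewise gives in this assay a limit of the assay, > 11000 nM. The steps among them are therefore not readable: a step that the two limits leave unreadable from compound 1 to compound 2, a step that the two limits leave unreadable from compound 2 to compound 3 and a step that the two limits leave unreadable from compound 1 to compound 3 all run between two limits. What the three values share is the limit of > 11000 nM in this assay, at which 3 of the 3 values shown sit.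

Compound 4 `Cc1ccc(S(=O)(=O)N[C@@H](CC(=O)NC(C)(C)C)C(=O)NCCNC(=O)c2ccc(F)c(F)c2)cc1` differs from compound 2 in one place: 3,4-difluorophenyl in place of phenyl on a carbonyl carbon. Within the data shown here, none of the measured steps puts a size on a change of this kind, since each of them is hidden by the limit. Given that compound 2 sits at > 11000 nM and compound 1 and compound 3 do the same, compound 4 is expected to show no step beyond the scatter, a step that the limit leaves unreadable from compound 2 to compound 4, and most likely to return only a limit again. The estimate for compound 4 in this assay is 20000 nM, with a range from 8000 nM to 60000 nM.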

Compound 4, half-maximal effective concentration: > 11000 nM
Compound 4 was reported as a limit; the forecaster's own chance of this, stated with the estimate: 80%; the middle value is on the limit's open side.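

In this assay compound 4 gives > 11000 nM, a limit of the assay and not a number. The steps to compound 4 from compound 1, compound 2 and compound 3 therefore cannot be read, and the four compounds share: the limit of > 11000 nM in this assay, at which 4 of the 4 values shown sit. The compounds shown leave open what concentration any of them needs for the half-maximal effect in this assay, and so how large any of these changes on the carbonyl carbon is.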